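Meta-substituent removal on the anilino ring of the series

This account rests on a few compounds, and the source may have more. Where it says the series, first, only, none or still open, it means among the compounds named here.

Measured compounds:
compound 1 `N#Cc1c(Nc2cccc(Cl)c2)nc(SCc2cn(Cc3ccccc3Cl)nn2)nc1-c1ccccc1` — 24400 nM
compound 2 `Cc1cccc(Nc2nc(SCc3cn(Cc4ccccc4Cl)nn3)nc(-c3ccccc3)c2C#N)c1` — 15600 nM

In a functional assay on ECa-109 cells (Homo sapiens) for inhibition, read by MTT assay, with a stated time of 72 h (on this read-out lower numbers stand for stronger inhibition and higher numbers for weaker inhibition), compound 2 gives 15600 nM and compound 1 gives 24400 nM. Compound 2 has the lower of the two numbers, but the step of a 1.6-fold lower number from compound 1 to compound 2 (0.19 log units; within the scatter) is within the scatter, so the two compounds cannot be ordered on this read-out.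

Compound 3 `N#Cc1c(Nc2ccccc2)nc(SCc2cn(Cc3ccccc3Cl)nn2)nc1-c1ccccc1` is not yet measured. The change from compound 2 is hydrogen in place of methyl on an aromatic carbon, meta to a large group, so the 3-methylphenyl becomes phenyl. Going by the values given here, no measured step in this assay removes a substituent from that ring; the only step available, from chloro to methyl, was within the scatter. With nothing pointing either way, the expected step of a 1.3-fold higher number from compound 2 to compound 3 (0.11 log units; within the scatter) is none beyond the scatter. Compound 3 is therefore estimated at 20000 nM, with a range from 7000 nM to 55000 nM.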

Compound 3, half-maximal inhibitory concentration: > 64000 nM
Compound 3: a limit, no number; the forecaster's own chance of this, stated with the estimate: 10%; at least 3.2-fold (0.50 log units) between middle value and limit.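

In this assay compound 3 gives a limit and not a number: the limit of > 64000 nM in this assay, at which 1 of the 3 values shown sits. Taking the substituent off this ring carbon is a change of a different order from exchanging it: loss of the methyl gives an at least 4.1-fold higher number from compound 2 to compound 3 (0.61 log units; beyond the scatter), and loss of the chloro gives an at least 2.6-fold higher number from compound 1 to compound 3 (0.41 log units; beyond the scatter), whereas the exchange of chloro for methyl gave a 1.6-fold lower number from compound 1 to compound 2 (0.19 log units; within the scatter). Across these three compounds, then, what counts at this place is whether a substituent is present at all, and the choice between chloro and methyl cannot be told apart.

As far as these compounds go, how far compound 3 lies past its limit stays open, so the full size of both steps is unknown. Also open, from the compounds shown here alone, is whether a methoxy, a trifluoromethyl or an amine at the same place would keep a measurable number, or improve on compound 2.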